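A few compounds are considered here, and "the series" means these few. Any claim that something is new, unique, unknown or untested is made for them only; others in the source may bear on it.

Measured so far in a physicochemical assay for solubility, at pH 7.4; a higher number here means a more soluble compound, a lower number a less soluble compound:
- compound 1 `Cc1cc(N)n(-c2nc(-c3ccccc3)cc(=O)[nH]2)n1`: 180000 nM
- compound 2 `Cc1cc(C)n(-c2nc(-c3ccc(F)cc3)cc(=O)[nH]2)n1`: 35000 nM
- compound 3 `Cc1cc(N)n(-c2nc(C(F)(F)F)cc(=O)[nH]2)n1`: 200000 nM

Within this set compound 3 and compound 1 sit together at the top, within the scatter of each other, as shown by the step of a 1.1-fold higher number from compound 1 to compound 3 (0.05 log units; within the scatter). Among the compounds with values here, compound 2, the only one without the amino group on its pyrazole, lies below both, and its gap to compound 3 is beyond the scatter.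

The next compound, compound 4 `Cc1cc(Nc2ccccn2)n(-c2nc(C(F)(F)F)cc(=O)[nH]2)n1`, keeps the trifluoromethyl core of compound 3 and changes only the amino group: pyridin-2-yl in place of hydrogen on a nitrogen on an aromatic ring. Within the data shown here, none of the measured steps covers a change of this kind; the single step in hand, a 1.1-fold higher number from compound 1 to compound 3 (0.05 log units; within the scatter), swaps a group on an aromatic carbon and was within the scatter, so it gives no guide to this change on a nitrogen. The series itself is narrow in structure and spans only a modest range in this assay. Among the measured compounds shown here, with no directly comparable step, the expectation for compound 4 is a drop from compound 3 of about a 5.0-fold lower number from compound 3 to compound 4 (0.70 log units; beyond the scatter), held with low confidence and a wide range. The estimate for compound 4 in this assay is therefore 40000 nM, between 8000 nM and 160000 nM.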

Compound 4, solubility: 25000 nM
The estimate for compound 4 lay 1.6-fold (0.20 log units) above the measured number; the measured number falls inside the stated range.
By their numbers in this assay, from the lowest: compounds 4 and 2 (each within the scatter of the next); then compounds 1 and 3 (each within the scatter of the next).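

In this assay, within the data shown here, the nitrogen of the amino group is the first place where a single change gives a step beyond the scatter: pyridin-2-yl in place of hydrogen on this nitrogen gives a clear fall (an 8.0-fold lower number from compound 3 to compound 4 (0.90 log units; beyond the scatter)). Among these compounds, the only earlier single change, trifluoromethyl in place of phenyl on an aromatic carbon, stayed within the scatter (a 1.1-fold higher number from compound 1 to compound 3 (0.05 log units; within the scatter)), so the series is no longer flat across every position changed, although each position rests on one step alone. No measurement in hand bears on the reason for the fall at this nitrogen, and the step records its size and direction only.

Still open, as far as these compounds go, is whether the fall belongs to pyridin-2-yl itself or would follow any group on this nitrogen, such as a methyl, an acetyl or a plain phenyl, or a pyridine ring carrying a carboxylic acid or a dimethylamino group. Also open, from the compounds shown here alone, is whether the same change on the phenyl-bearing core of compound 1 would give a step of similar size, which would show whether the effect at this nitrogen carries over between the two cores.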